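Proline ester in place of lysine ester on a nucleoside

This account rests on a few compounds, and the source may have more. Where it says the series, first, only, none or still open, it means among the compounds named here.

Of the compounds shown here, three have been measured in an ADME assay on a cell-free system (plasma, Homo sapiens) for metabolic stability; a lower number here means that the compound disappears faster, a higher number that the compound lasts longer. Compound 1 `NCCCC[C@H](N)C(=O)OC[C@H]1O[C@@H](n2cc(F)c(=O)[nH]c2=O)C[C@@H]1OC(=O)[C@@H](N)CCCCN` gives 0.492 h, and compound 2 `NCCCC[C@H](N)C(=O)OC[C@H]1O[C@@H](n2cc(F)c(=O)[nH]c2=O)C[C@@H]1O` gives 0.647 h, the highest of the three numbers, while compound 3 `CN(C)Cc1cccc(C(=O)OCCOCn2cnc3c(=O)[nH]c(N)nc32)c1` gives 0.117 h. Among the measured compounds shown here, compound 2 stands nearest to compound 1 and furthest from compound 3; the one counted step, a 1.3-fold higher number from compound 1 to compound 2 (0.12 log units; within the scatter), lies within the scatter, whereas the gap from compound 2 down to compound 3 lies beyond it.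

Compound 4 `O=C(OC[C@H]1O[C@@H](n2cc(F)c(=O)[nH]c2=O)C[C@@H]1O)[C@@H]1CCCN1` is the next one to be measured in this assay. It differs from compound 2 in one place: pyrrolidin-2-yl in place of 1,5-diaminopentyl on a carbonyl carbon. For the measured compounds named here, no measured step covers an exchange of this kind on the carbonyl carbon; the only counted step, between compound 1 and compound 2, concerns a different position and was within the scatter. The remaining comparison, to compound 3, involves a different core and cannot be read as a step. On this basis the author expects no step beyond the scatter, with a 1.2-fold higher number from compound 2 to compound 4 (0.06 log units; within the scatter) as the most likely outcome. Compound 4 is therefore estimated at 0.75 h, with a range from 0.3 h to 2 h.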

Compound 4, half-life: 0.095 h
The estimate for compound 4 lay 7.9-fold (0.90 log units) above the measured number; measured number outside the range, below it.
By their numbers in this assay, from the lowest: compounds 4 and 3 (each within the scatter of the next); then compounds 1 and 2 (each within the scatter of the next).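

In this assay, among the compounds shown here, the group on this carbonyl carbon proves able to move the number: the exchange of 1,5-diaminopentyl for pyrrolidin-2-yl gives a 6.8-fold lower number from compound 2 to compound 4 (0.83 log units; beyond the scatter) and is the first step that touches this position. The earlier compounds shown here had offered only a 1.3-fold higher number from compound 1 to compound 2 (0.12 log units; within the scatter) and that step, on an oxygen on a saturated carbon elsewhere in the molecule, gave no sign that the ester substituents could matter this much. Nothing measured here bears on what lies behind the drop.

The exchange alters several things at once, since an open chain gives way to a five-membered non-aromatic ring and the heavy-atom, nitrogen and hydrogen-bond counts all shrink, so the compounds shown cannot say which of these changes goes with the lower number. Going by these compounds, it remains open whether a shorter open chain carrying an amine on the same carbonyl carbon would stay near compound 2 or fall toward compound 4, and whether pyrrolidin-2-yl would give a similar step with a second ester on the other oxygen of the shared core.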